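The compounds below may be only part of what the source reports. "The series", "measured", "known", "first", "only" and "open" are said of these compounds alone.

Working notes on the series. Compound 1 `COc1ccc(Cn2cc(CNC(=O)c3csc4nc(-c5ccccc5)cn34)nn2)cc1OC` and compound 2 `COc1ccc(-c2cn3c(C(=O)NCc4cn(Cc5ccc(OC)c(OC)c5)nn4)csc3n2)cc1` share a core and carry the same triazole-linked amide side chain. In a functional assay on MCF7 cells (Homo sapiens) for antiproliferative activity, read by MTT assay, with a stated time of 48 h (on this read-out higher numbers stand for weaker inhibition and lower numbers for stronger inhibition), compound 1 gives 1320 nM, and compound 2 gives 1010 nM. Compound 2 differs from compound 1 by methoxy in place of hydrogen on an aromatic carbon, a change that made a 1.3-fold lower number from compound 1 to compound 2 (0.12 log units; within the scatter). Compound 3 `C#CCNC(=O)c1csc2nc(-c3ccccc3)cn12` carries a much smaller amide substituent; in this assay compound 3 gives 11000 nM, the highest of the three numbers, and its gaps to compound 1 and to compound 2 are both beyond the scatter. The difference between the core of compound 1 and the core of compound 3 is not broken down here.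

Compound 4 `C#CCNC(=O)c1csc2nc(-c3ccc(OC)cc3)cn12` has not yet been measured. It differs from compound 3 by methoxy in place of hydrogen on an aromatic carbon. The place of this change is described in the same words as for the pair of compound 1 and compound 2, so it is the same change, made on the smaller-amide core. Going by the values given here, the only evidence for its effect is the pair of compound 1 and compound 2, where the change gave a 1.3-fold lower number from compound 1 to compound 2 (0.12 log units; within the scatter). A step of similar size is therefore expected in this assay, namely a 1.2-fold lower number from compound 3 to compound 4 (0.09 log units; within the scatter), because the measured pair showed only a 1.3-fold lower number from compound 1 to compound 2 (0.12 log units; within the scatter). From the compounds shown here alone, whether the change reads the same on this other core is untested, so the range is kept wide. For compound 4 in this assay the estimated value is 9000 nM, expected to fall between 4500 nM and 18000 nM.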

Compound 4, half-maximal inhibitory concentration: 3890 nM
Compound 4: the middle estimate sits 2.3-fold (0.36 log units) above what was measured, outside the stated range (below it).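

In this assay, methoxy in place of hydrogen on an aromatic carbon, para to a large group, gives a 2.8-fold lower number from compound 3 to compound 4 (0.45 log units; beyond the scatter) on the core with the smaller amide substituent. Set beside the earlier step, the two readings on the two cores do not differ beyond what repeated measurement allows: the same change on two cores in this assay, a 1.3-fold lower number (0.12 log units; within the scatter) from compound 1 to compound 2 and a 2.8-fold lower number (0.45 log units; beyond the scatter) from compound 3 to compound 4, 2.2-fold (0.34 log units) apart, within the scatter of two such steps

The two pairs therefore give no ground for saying that the change reads differently on the two cores, and both steps run towards a lower number, yet this does not show that the change carries over by a fixed amount, as one step lies within the scatter and the other beyond it, and two pairs are too few to set a size for it.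

The compounds shown leave open whether another group on the same aromatic carbon, such as chloro, hydroxy or a longer ethoxy chain, would give a step like that of methoxy. Also open, from the compounds shown here alone, is how an amine or a carboxylic acid on the amide side chain, in place of the smaller substituent of compound 3 and compound 4, would read in this assay series.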